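The source may report more compounds than this note shows. Statements on the series, on what has been measured and on what is new or still open speak of the compounds shown alone.

Working notes on the series. In an assay on isolated protein for inhibition of lysosomal alpha-glucosidase (Rattus norvegicus), with stated times of 5 min and 10 min, tested at 200 uM (a higher number here means more inhibition at the concentration tested (going by the name of the read-out), a lower number less inhibition), compound 1 `Oc1ccccc1/C=N/c1ccc(Cl)cc1` gives 5.63%, while compound 2 `O=[N+]([O-])c1ccc(/N=C/c2ccccc2O)cc1` gives 95.6%. Among the measured compounds shown here, the single step measured so far, a number 90 percentage points higher from compound 1 to compound 2 (beyond the scatter), is the only guide to how changes on the ring that carries the imine nitrogen move this read-out. Compound 3 `Oc1ccc(Br)cc1/C=N/c1ccccc1` is reported in this assay only as "active" (no number reported), so there is no number for where it stands. Compound 4 `COc1ccc(/N=C/c2cc(Br)ccc2O)cc1` differs from compound 3 by methoxy in place of hydrogen on an aromatic carbon. For the measured compounds named here, no measured step involves a methoxy, and the step from compound 1 to compound 2 concerns a different group, so no size or direction can be read across from it. Compound 4 is estimated at 45% in this assay, expected between 5% and 90%.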

Compound 4, a percentage reported as inhibition, at one concentration (the size of the read-out at that concentration, not a potency): "active" (no number reported)
The entry for compound 4 holds no number; no gap can be computed for the estimate.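

Compound 3 and compound 4 both stand without a number, so no step can be read between them, and no evidence bears on this result. On these data alone, the size and direction of any change from methoxy in place of hydrogen remain open.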